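Replacing Pyrimidin-5-yl on the Ring Nitrogen

The source may hold more compounds than are shown below. What is called first, only, known or untested is meant among the compounds shown, and "the series" means these compounds.

Compound 3 `O[C@H](COCCOC[C@@H](O)Cc1cn(-c2cncnc2)nn1)Cc1ccc(-c2ccccc2)cc1` stands weakest among the measured compounds: in a functional assay on HCT-116 cells (Homo sapiens) for inhibition, read by MTT assay, with a stated time of 72 h (on this read-out lower numbers stand for stronger inhibition of growth and higher numbers for weaker inhibition of growth), compound 3 gives only a limit, > 100000 nM. Compound 1 `N#Cc1ccc(Cn2cc(C[C@H](O)COCCOC[C@@H](O)Cc3ccc(-c4ccccc4)cc3)nn2)cc1` gives 8800 nM and compound 2 `O[C@H](COCCOC[C@@H](O)Cc1cn(Cc2ccc(C(F)(F)F)cc2)nn1)Cc1ccc(-c2ccccc2)cc1` gives 2500 nM. The steps toward compound 3 were large, an at least 11-fold higher number from compound 1 to compound 3 (1.05 log units; beyond the scatter) and an at least 40-fold higher number from compound 2 to compound 3 (1.60 log units; beyond the scatter), so exchanging 4-cyanobenzyl or 4-(trifluoromethyl)benzyl for pyrimidin-5-yl on the aromatic nitrogen cost much activity. Compound 4 `O=c1[nH]c2ccc(-n3cc(C[C@H](O)COCCOC[C@@H](O)Cc4ccc(-c5ccccc5)cc4)nn3)cc2s1` reverses part of that: a group of 10 heavy atoms (7 carbon, 1 nitrogen, 1 oxygen, 1 sulfur; one five-membered aromatic ring with 2 hetero atoms, one six-membered aromatic ring of carbon only) in place of a group of 6 heavy atoms (4 carbon, 2 nitrogen; one six-membered aromatic ring with 2 hetero atoms), on an aromatic nitrogen. Those two steps suggest that a larger aromatic group at this position goes with stronger growth inhibition, so a move toward lower numbers is expected, though another limit remains possible. Compound 4 is therefore expected at 20000 nM, between 3000 nM and 100000 nM, a step of an at least 5.0-fold lower number from compound 3 to compound 4 (0.69 log units; beyond the scatter).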

Compound 4, concentration for 50% growth inhibition: 9200 nM
Beside the measured number, compound 4's estimate is 2.2-fold (0.34 log units) above it; the range from low to high includes it.
By their numbers in this assay, from the lowest: compound 2; then compounds 1 and 4 (each within the scatter of the next). At a limit, above all of these: compound 3.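

On the aromatic nitrogen, the two-ring group of compound 4 recovers growth inhibition in this assay, with an at least 10-fold lower number from compound 3 to compound 4 (1.03 log units; beyond the scatter), so activity here does not depend on a benzyl group. That group cannot be told apart from 4-cyanobenzyl, with a 1.0-fold higher number from compound 1 to compound 4 (0.02 log units; within the scatter), but it falls short of 4-(trifluoromethyl)benzyl, with a 3.7-fold higher number from compound 2 to compound 4 (0.57 log units; beyond the scatter). Compound 3 gives only a limit, so the first step is a minimum: the limit of > 100000 nM in this assay, at which 1 of the 4 values shown sits.

As far as these compounds go, whether the gain comes from the second ring or from the hydrogen-bond donor stays open. So does the effect of an amine or a carboxylic acid on the entering group.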